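Benzyloxy for methyl on the pendant aryl ring

The compounds below may be only part of what the source reports. "The series", "measured", "known", "first", "only" and "open" are said of these compounds alone.

Compound 2 `Cc1ccc(C2=NN(C(=S)Nc3ccccc3)C(c3ccc4c(c3)OCCO4)C2)cc1` sits at the high end of the two numbers seen so far: in a functional assay on A-375 cells (Homo sapiens) for antiproliferative activity, read by MTT assay, with a stated time of 48 h (a lower number here means a stronger inhibitor of growth, a higher number a weaker inhibitor of growth), compound 2 gives 6320 nM. Its nearest neighbour is compound 1 `S=C(Nc1ccccc1)N1N=C(c2ccccc2)CC1c1ccc2c(c1)OCCO2`, which in this assay gives 1850 nM; the change of methyl in place of hydrogen on an aromatic carbon carries a 3.4-fold higher number from compound 1 to compound 2 (0.53 log units; beyond the scatter). Compound 3 `S=C(Nc1ccccc1)N1N=C(c2ccc(OCc3ccccc3)cc2)CC1c1ccc2c(c1)OCCO2` has not yet been measured in this assay. It differs from compound 2 by benzyloxy in place of methyl on an aromatic carbon. Among the measured compounds shown here, only one measured step touches this position, and it concerns methyl, not benzyloxy: the step from compound 1 to compound 2 was modest and beyond the scatter in the weaker direction. Nothing measured tells how a benzyloxy at this place behaves, so the expectation leans on compound 2 alone, with wide uncertainty. The expected step of a 1.3-fold lower number from compound 2 to compound 3 (0.10 log units; within the scatter) is therefore kept small, with either direction open. Compound 3 is estimated at 5000 nM, with a range from 1500 nM to 16000 nM.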

Compound 3, concentration for 50% growth inhibition: 350 nM
Compound 3: the middle estimate sits 14-fold (1.15 log units) above what was measured; the measured number lies below the stated range.
By their numbers in this assay, from the lowest: compound 3; then compound 1; then compound 2.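

Notes on the position: in this assay, a substituent at this aromatic carbon, para to a large group, does not by itself weaken growth inhibition, as the rise seen with methyl, a 3.4-fold higher number from compound 1 to compound 2 (0.53 log units; beyond the scatter), is not repeated with benzyloxy, which gives a 5.3-fold lower number from compound 1 to compound 3 (0.72 log units; beyond the scatter). The identity of the group therefore counts for more here than the mere presence of a substituent, with an 18-fold lower number from compound 2 to compound 3 (1.26 log units; beyond the scatter) separating the two substituted compounds, so that methyl and benzyloxy move the number in opposite directions relative to hydrogen across these three compounds. Nothing available explains this reversal or ties it to any property of either group.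

The compounds shown do not separate the contributions of the ether oxygen and the terminal phenyl ring within benzyloxy, a question that methoxy, a phenyl group attached directly to the ring, or a longer chain such as phenethyloxy at the same carbon would address. Also open, going by these compounds, is whether substituents on the terminal phenyl ring, such as fluorine or an amine, keep the lower number seen with compound 3 and whether the change carries over to other substituents on the shared core.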